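A few compounds are considered here, and "the series" means these few. Any claim that something is new, unique, unknown or untested is made for them only; others in the source may bear on it.

Measured so far:
compound 1 `COc1ccc(-c2nc(CNC(=O)C3=NNC(=O)CC3)sc2-c2ccc(OC)cc2)cc1` — 7.3 uM
compound 2 `COc1ccc(-c2nc(C(=O)N3CCNC(CCO)C3)sc2-c2ccc(OC)cc2)cc1` — 9.5 uM

Both compounds were tested in a functional assay (aorta) with Rattus norvegicus as the target; a lower number here means that less compound is needed, a higher number that more compound is needed for the effect. Compound 1 gives 7.3 uM and holds the lowest of the two numbers. Compound 2 gives 9.5 uM, which lies within the usual scatter of compound 1, so the two cannot be told apart on these numbers. Going by the values given here, no step between measured compounds has been worked out, so there is no measured change to lean on.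

Compound 3 `COc1ccc(-c2nc(CCC(=O)O)sc2-c2ccc(OC)cc2)cc1` has not yet been measured. It differs from compound 1 in one place: a group of 4 heavy atoms (2 carbon, 2 oxygen; no ring) in place of a group of 10 heavy atoms (5 carbon, 3 nitrogen, 2 oxygen; one six-membered non-aromatic ring with 2 hetero atoms), on a saturated chain carbon bound to an aromatic carbon. The two measured compounds carry quite different side groups on the shared core yet give numbers within the scatter of each other, so one large change at this part of the molecule passed without a shift beyond the scatter. A cautious reading therefore expects a step from compound 1 to compound 3 in this assay of modest size, most likely toward a somewhat higher number. The value of compound 3 in this assay is expected to be 15 uM, within a range from 4 uM to 60 uM. This estimate amounts to an expected step of a 2.1-fold higher number from compound 1 to compound 3 (0.31 log units; beyond the scatter).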

Compound 3, concentration for half-maximal effect: > 100 uM
Compound 3: a limit, no number; the forecaster's own chance of this, stated with the estimate: 25%; middle value at least 6.6-fold (0.82 log units) from the limit.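

In this assay compound 3 gives > 100 uM, which is a limit of the assay and not a number. Replacing the side group of compound 1, with its six-membered non-aromatic ring, by the much smaller carboxymethyl group, on a saturated chain carbon bound to an aromatic carbon, gives an at least 13-fold higher number from compound 1 to compound 3 (1.13 log units; beyond the scatter), so this position is not free to take any group without a clear loss in this test. Going by these compounds alone, compound 1 and compound 2 alone gave no measured step at all, and their numbers lay within the scatter of each other, so this is the first sign that a single change here can move the result by a large amount.

The ring, the amide and the extra nitrogen atoms all leave in this one change while the carboxymethyl group enters, so the compounds shown cannot say which of these accounts for the step. As far as these compounds go, whether a methyl ester or a primary amine in place of the carboxymethyl group, or a longer chain ending in either of them, would bring the number back toward that of compound 1 also remains open.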